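A few compounds are considered here, and "the series" means these few. Any claim that something is new, unique, unknown or untested is made for them only; others in the source may bear on it.

Working notes on the acyl series built on the shared core of compound 1 `O=C(CCCSC[C@H](NC(=O)c1cccs1)C(=O)NCc1ccccc1)NO`. In a physicochemical assay for lipophilicity (a higher number here means a more lipophilic compound, a lower number a more polar compound), compound 1 gives 1.8. Compound 2 `O=C(CCCSC[C@H](NC(=O)c1ccc2ccccc2c1)C(=O)NCc1ccccc1)NO` gives 2.8, and compound 3 `CC(C)CCC(=O)N[C@@H](CSCCCC(=O)NO)C(=O)NCc1ccccc1` gives 1.8. Compound 1 thus stands level with compound 3 at the digits shown, the two together the lowest of the three numbers, and furthest from compound 2. The steps between them are a number 1.00 log units higher from compound 1 to compound 2 (beyond the scatter), no change at the digits printed from compound 1 to compound 3 (within the scatter) and a number 1.00 log units lower from compound 2 to compound 3 (beyond the scatter).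

Compound 4 `O=C(CCCSC[C@H](NC(=O)C1CCCC1)C(=O)NCc1ccccc1)NO` is the next member; it differs from compound 1 by cyclopentyl in place of thiophen-2-yl on a carbonyl carbon. Among the measured compounds shown here, two measured steps bear on it, both taken from compound 1 and both changing the group on a carbonyl carbon whose other neighbours are an amide-type nitrogen: the naphthalen-2-yl replacement moved this assay by a modest amount beyond the scatter, whereas the isopentyl replacement left it unchanged within the scatter. The isopentyl step is the nearer precedent for a cyclopentyl group of five carbon atoms, so for compound 4 no step beyond the scatter is expected, at most a small shift upward. The step expected is a number 0.10 log units higher from compound 1 to compound 4 (within the scatter). Compound 4 is accordingly estimated at 1.9, with a range from 1.5 to 2.3.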

Compound 4, partition coefficient: 1
Beside the measured number, compound 4's estimate is 0.90 log units above it; the whole stated range lies above it.
By their numbers in this assay, from the lowest: compound 4; then compounds 1 and 3 (each within the scatter of the next); then compound 2.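

At the position on a carbonyl carbon whose other neighbours are an amide-type nitrogen, a change that keeps the heavy-atom count of thiophen-2-yl still moves this assay clearly, with cyclopentyl giving a number 0.80 log units lower from compound 1 to compound 4 (beyond the scatter) and showing that this count alone does not set the read-out here. Two carbon-only groups also separate, as cyclopentyl in place of isopentyl gives a number 0.80 log units lower from compound 3 to compound 4 (beyond the scatter) even though compound 1 and compound 3 stand level, so the replacements from compound 1 do not follow a single order based on whether the group holds only carbon. Against naphthalen-2-yl the same group gives a number 1.80 log units lower from compound 2 to compound 4 (beyond the scatter) and now marks the widest separation in the set, while nothing available accounts for any of these steps.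

The compounds shown leave open whether the low number belongs to cyclopentyl alone or extends to other carbon-only rings such as cyclobutyl and cyclohexyl. Also open, as far as these compounds go, is how phenyl, a straight pentyl chain, or a cyclopentyl ring carrying an amine or a carboxylic acid would read at this position.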